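Trifluoromethyl added to an aromatic carbon in two cores

The source may hold more compounds than are shown below. What is called first, only, known or untested is meant among the compounds shown, and "the series" means these compounds.

Compound 1 `CNc1nc(C(F)(F)F)c(C(=O)N/N=C/c2cccc(C(F)(F)F)c2)s1` in a functional assay on HepG2 cells (Homo sapiens) for inhibition, read by MTT assay, with a stated time of 72 h (on this read-out lower numbers stand for stronger inhibition and higher numbers for weaker inhibition), returns only a limit, > 100 ug/mL. Compound 2 `Cc1nc(N(C)C(=O)NC(=O)c2c(F)cccc2F)sc1C(=O)N/N=C/c1ccccc1` in this assay gives 54.3 ug/mL. Compound 3 `Cc1nc(N(C)C(=O)NC(=O)c2c(F)cccc2F)sc1C(=O)N/N=C/c1ccc(C(F)(F)F)cc1` in this assay returns only a limit, > 100 ug/mL. The difference between the cores of compound 1 and compound 2 is not broken down here. The change trifluoromethyl in place of hydrogen on an aromatic carbon gives an at least 1.8-fold higher number from compound 2 to compound 3 (0.26 log units; that floor lies within the scatter), a floor set because of the limit of > 100 ug/mL in this assay, at which 2 of the 3 values shown sit. Compound 4 `CNc1nc(C(F)(F)F)c(C(=O)N/N=C/c2cc(C(F)(F)F)cc(C(F)(F)F)c2)s1` carries the same kind of change on the core of compound 1, (trifluoromethyl in place of hydrogen on an aromatic carbon), though here the place is meta to a large group and meta to a trifluoromethyl group rather than para to a large group. Since compound 1 already sits at the limit > 100 ug/mL, compound 4 is expected to remain there, a step that the limit leaves unreadable from compound 1 to compound 4. The estimate for compound 4 in this assay is 150 ug/mL.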

Compound 4, half-maximal inhibitory concentration: > 100 ug/mL
Compound 4 was reported as a limit (the forecaster's own chance of this, stated with the estimate: 85%); the middle value lies beyond the limit too.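

Compound 1 and compound 4 both return limits, and no new step can be read between them. The compounds shown leave open whether trifluoromethyl in place of hydrogen on an aromatic carbon changes the read-out on the core of compound 1 at all.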